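Replacing bromo with trifluoromethyl in a short-lived compound

A few compounds are considered here, and "the series" means these few. Any claim that something is new, unique, unknown or untested is made for them only; others in the source may bear on it.

Within the data shown here, in an ADME assay on microsomes from liver (Rattus norvegicus) for metabolic stability (on this read-out higher numbers stand for a longer-lived compound and lower numbers for a shorter-lived compound), compound 2 (`CCS(=O)(=O)c1ccc(CNC(=O)c2ccc3c(c2)cc(Cc2ccccc2Br)n3C(C)C)cc1`) gives 0.2 h, the lower of the two numbers known, beyond the scatter from compound 1 (`CCS(=O)(=O)c1ccc(CNC(=O)c2ccc3c(c2)cc(Cc2ccc(Cl)cc2C(F)(F)F)n3C2CC2)cc1`), which gives 1.7 h. Compound 3 (`CCS(=O)(=O)c1ccc(CNC(=O)c2ccc3c(c2)cc(Cc2ccccc2C(F)(F)F)n3C(C)C)cc1`) departs from compound 2 in one place: trifluoromethyl in place of bromo on an aromatic carbon, with trifluoromethyl in place of bromo on an aromatic carbon, ortho to a large group. Compound 1, at 1.7 h, also carries a trifluoromethyl but differs elsewhere too, so it offers only a hint of direction. The step expected in this assay is a modest rise, a 2.0-fold higher number from compound 2 to compound 3 (0.30 log units; within the scatter), at about the edge of the scatter. Compound 3 is estimated at 0.4 h, within a range of 0.15 h to 1 h.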

Compound 3, half-life: 0.717 h
Compound 3: middle estimate off by 1.8-fold (0.25 log units), on the low side; the measured number falls inside the stated range.
By their numbers in this assay, from the lowest: compound 2; then compound 3; then compound 1.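

In this assay, trifluoromethyl in place of bromo on this aromatic carbon, ortho to a large group, gives a 3.6-fold higher number from compound 2 to compound 3 (0.55 log units; beyond the scatter) and so lifts the half-life beyond the scatter. Among these compounds, this is the first comparison here in which only one place changes, so the rise can be tied to this replacement alone, at least on the core that compound 2 and compound 3 share. Going by these compounds, whether a nitrile or a methoxy group at this position would match trifluoromethyl remains open. No measurement shown accounts for the step.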